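Urea series on a shared heteroaryl core: toward compound 3

The compounds below may be only part of what the source reports. "The series", "measured", "known", "first", "only" and "open" are said of these compounds alone.

compound 1 `O=C(NC1CCCCC1)N1CCN(c2nc(-c3ccc4ccccc4n3)no2)CC1`: 53 nM
compound 2 `O=C(NC1CCS(=O)(=O)CC1)N1CCC(c2nc(-c3ccc4ccccc4n3)no2)CC1`: 360 nM

Two compounds are measured in a functional assay on Shh Light II cells (Mus musculus) for inhibition, read by a luciferase reporter; on this read-out lower numbers stand for stronger inhibition and higher numbers for weaker inhibition. Compound 1 gives 53 nM, while compound 2 gives 360 nM, the higher of the two numbers, and the gap between compound 1 and compound 2 lies beyond the scatter. Compound 3 `O=C(Nc1ncccc1Cl)N1CCC(c2nc(-c3ccc4ccccc4n3)no2)CC1` carries the change (3-chloropyridin-2-yl in place of 1,1-dioxothian-4-yl on an amide-type nitrogen). Within the data shown here, no measured pair shows this exchange, so its size is open. Because compound 1 stands at 53 nM without the 1,1-dioxothian-4-yl group, compound 3 is expected to improve on compound 2 by a modest step, a 2.4-fold lower number from compound 2 to compound 3 (0.38 log units; beyond the scatter). Compound 3 is estimated at 150 nM, within a range of 40 nM to 600 nM.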

Compound 3, half-maximal inhibitory concentration: 2800 nM
Compound 3: middle estimate off by 19-fold (1.27 log units), on the low side, and the stated range ends below it.
By their numbers in this assay, from the lowest: compound 1; then compound 2; then compound 3.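

At this amide-type nitrogen, the substituent clearly affects inhibition in this assay: replacing 1,1-dioxothian-4-yl with 3-chloropyridin-2-yl gives a 7.8-fold higher number from compound 2 to compound 3 (0.89 log units; beyond the scatter) and weaker inhibition. In this single pair, the aromatic ring bearing chlorine is the less favourable of the two groups at this place. No supporting data are available to explain the loss.

On these data alone, whether the loss follows the chlorine, the ring nitrogen or the aromatic ring itself remains open. Unsubstituted phenyl and pyridin-2-yl groups at this place would help separate these features.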